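Chalcone-bearing aminothiazoles: removing a methoxy from the aryl ring

The compounds below may be only part of what the source reports. "The series", "measured", "known", "first", "only" and "open" are said of these compounds alone.

Measured compounds:
compound 1 `Cc1ccccc1Nc1nc(C)c(C(=O)/C=C/c2ccccc2)s1` in a functional assay on Bel-7402 cells (Homo sapiens) for cytotoxicity, read by MTT assay (a lower number here means a stronger inhibitor, a higher number a weaker inhibitor), gives > 25000 nM, a limit of the assay.
compound 2 `Cc1nc(Nc2ccccc2)sc1C(=O)/C=C/c1ccccc1` in this assay gives > 25000 nM, a limit of the assay.
compound 3 `COc1cccc(/C=C/C(=O)c2sc(Nc3ccc(C)cc3)nc2C)c1` in this assay gives > 25000 nM, a limit of the assay.

Compound 3 therefore stands only at a limit in this assay, and the same holds for its two companions: the limit of > 25000 nM in this assay, at which 3 of the 3 values shown sit. Among the compounds with values here, the only step between measured compounds that differ in one place, a step that the two limits leave unreadable from compound 1 to compound 2, is itself unreadable, since both ends sit at that limit.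

Compound 4 `Cc1ccc(Nc2nc(C)c(C(=O)/C=C/c3ccccc3)s2)cc1` differs from compound 3 by hydrogen in place of methoxy on an aromatic carbon. Within the data shown here, no measured step bears directly on this change, and the one step that exists gives no size. With every value shown sitting at the limit, compound 4 is expected to sit there as well, so that the step from compound 3 is estimated as a step that the limit leaves unreadable from compound 3 to compound 4. Compound 4 is accordingly expected to give about 40000 nM in this assay, within a range from 10000 nM to 200000 nM, most probably reported only as a limit.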

Compound 4, half-maximal inhibitory concentration: > 25000 nM
Compound 4: a limit, no number (the forecaster's own chance of this, stated with the estimate: 85%); the middle value lies beyond the limit too.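

Compound 4 gives > 25000 nM in this assay, a limit of the assay, so none of its steps from compound 1, compound 2 or compound 3 can be read: the limit of > 25000 nM in this assay, at which 4 of the 4 values shown sit. The compounds shown leave open whether the methoxy, the methyl or the place of the methyl changes the result in this assay at all, and by how much.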